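Acid versus ester in a styrylsulfonamide anilino series

The compounds below may be only part of what the source reports. "The series", "measured", "known", "first", "only" and "open" are said of these compounds alone.

Three compounds have been measured in a functional assay on DU-145 cells (Homo sapiens) for cytotoxicity, read by trypan blue exclusion, with a stated time of 96 h; a lower number here means a stronger inhibitor, a higher number a weaker inhibitor:

compound 1, `COC(=O)C(Nc1cc(NS(=O)(=O)/C=C/c2c(OC)cc(OC)cc2OC)ccc1OC)c1ccc(F)cc1`, gives 2500 nM
compound 2, `COC(=O)C(Nc1cc(NS(=O)(=O)/C=C/c2c(OC)cc(OC)cc2OC)ccc1OC)c1ccc(Cl)cc1`, gives 5000 nM
compound 3, `COc1cc(OC)c(/C=C/S(=O)(=O)Nc2ccc(OC)c(NC(C(=O)O)c3ccc(F)cc3)c2)c(OC)c1`, gives 75 nM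

Compound 3 and compound 1 share a core that differs by hydrogen in place of methyl on an oxygen next to a carbonyl group; the step between them is a 33-fold lower number from compound 1 to compound 3 (1.52 log units; beyond the scatter), and between compound 2 and compound 3 it is a 67-fold lower number from compound 2 to compound 3 (1.82 log units; beyond the scatter). Compound 4, `COc1cc(OC)c(/C=C/S(=O)(=O)Nc2ccc(OC)c(NC(C(=O)O)c3ccc(Cl)cc3)c2)c(OC)c1`, is not yet measured and differs from compound 3 by chloro in place of fluoro on an aromatic carbon. The same change, (chloro in place of fluoro on an aromatic carbon), has been made once already, where it gave a 2.0-fold higher number from compound 1 to compound 2 (0.30 log units; within the scatter). The place of the change reads the same in both pairs, so this is the same change carried onto the core of compound 3. For compound 4 a step of a 2.0-fold higher number from compound 3 to compound 4 (0.30 log units; within the scatter) is expected in this assay, resting on the earlier step of a 2.0-fold higher number from compound 1 to compound 2 (0.30 log units; within the scatter). Compound 4 is therefore estimated at 150 nM, between 50 nM and 450 nM.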

Compound 4, half-maximal inhibitory concentration in the DU-145 assay: 75 nM
For compound 4 the middle estimate is 2.0-fold (0.30 log units) above the measured one; low and high end bracket the measured number.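

In the DU-145 assay compound 3 gives 75 nM and compound 4 gives 75 nM. In the DU-145 assay, chloro in place of fluoro on the acid core gives no change at the digits printed from compound 3 to compound 4 (within the scatter), and this agrees with the step on the ester core: the same change on two cores in the DU-145 assay, a 2.0-fold higher number (0.30 log units; within the scatter) from compound 1 to compound 2 and no change at the digits printed (within the scatter) from compound 3 to compound 4, 2.0-fold (0.30 log units) apart, within the scatter of two such steps

Hydrogen in place of methyl on the ester oxygen also carries across the two halogens, with a 67-fold lower number from compound 2 to compound 4 (1.82 log units; beyond the scatter), while the step that also exchanges the halogen gives a 33-fold lower number from compound 1 to compound 4 (1.52 log units; beyond the scatter): the same change on two cores in the DU-145 assay, a 33-fold lower number (1.52 log units; beyond the scatter) from compound 1 to compound 3 and a 67-fold lower number (1.82 log units; beyond the scatter) from compound 2 to compound 4, 2.0-fold (0.30 log units) apart, within the scatter of two such steps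

This shows that the acid compounds keep their lower numbers with either halogen and that chloro and fluoro are not told apart on these two cores, but it shows nothing for any other core. In a physicochemical assay for solubility (on this read-out lower numbers stand for lower solubility and higher numbers for higher solubility), compound 3 gives 10000 ug/mL and compound 4 gives 10000 ug/mL; in the physicochemical assay the step reads no change at the digits printed from compound 3 to compound 4 (within the scatter).

Still open, going by these compounds, is how bromo or trifluoromethyl in place of the halogen would read. Also open, on these data alone, is whether an amide or a nitrile in place of the carboxylic acid would hold the numbers of compound 3 and compound 4.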